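Lipophilicity notes: fluorinated dimethylphenyl amide in the series

This account rests on a few compounds, and the source may have more. Where it says the series, first, only, none or still open, it means among the compounds named here.

Two members of the series have been measured in a physicochemical assay for lipophilicity, read by HPLC, in phosphate buffer, measured as chromatographic lipophilicity, at pH 7.4; on this read-out lower numbers stand for lower lipophilicity and higher numbers for higher lipophilicity. Compound 1 `COc1ccc2nc(C)cc(OCC(=O)Nc3c(C)cccc3C)c2c1` gives 4.55, and compound 2 `COc1ccc(NC(=O)COc2cc(C)nc3ccc(OC)cc23)cc1` gives 4.22. For the measured compounds named here, the single measured step, a number 0.33 log units lower from compound 1 to compound 2 (beyond the scatter), places compound 2 as the lower of the two numbers, with compound 1 standing beyond the scatter above it.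

The next compound, compound 3 `COc1ccc2nc(C)cc(OCC(=O)Nc3cc(C)c(F)c(C)c3)c2c1`, differs from compound 2 in one place: 4-fluoro-3,5-dimethylphenyl in place of 4-methoxyphenyl on an amide-type nitrogen. Going by the values given here, the only step that bears on this change is the one from compound 1 to compound 2, in which a dimethylphenyl on the amide-type nitrogen gave way to the methoxyphenyl; the present change removes that same methoxyphenyl and brings in a dimethylphenyl carrying a fluorine, with no hydrogen-bond acceptor left in the group.

On this basis compound 3 is expected to run above compound 2 in this assay, because a number 0.33 log units lower from compound 1 to compound 2 (beyond the scatter) went downward when the methoxyphenyl arrived, and the added fluorine is expected to widen rather than cancel the reversal. The expected step is a number 0.58 log units higher from compound 2 to compound 3 (beyond the scatter). Compound 3 is estimated at 4.8, within 4.45 to 5.15.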

Compound 3, distribution coefficient: 5.5
Estimate against measurement, compound 3: 0.70 log units below, outside the stated range (above it).
By their numbers in this assay, from the lowest: compound 2; then compound 1; then compound 3.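

In this assay the group on an amide-type nitrogen moves the number over a far wider span than the earlier pair showed, with a number 1.28 log units higher from compound 2 to compound 3 (beyond the scatter) on 4-fluoro-3,5-dimethylphenyl in place of 4-methoxyphenyl. The two dimethylphenyl-type groups are not interchangeable at this position either, with a number 0.95 log units higher from compound 1 to compound 3 (beyond the scatter) on 4-fluoro-3,5-dimethylphenyl in place of 2,6-dimethylphenyl, so the earlier step cannot be read as a simple contrast of methoxyphenyl against dimethylphenyl. No evidence at hand explains either step.

Going by these compounds, the fluorine and the placing of the two methyl groups change together in these compounds, so their separate shares in the higher number stay open, and a plain 3,5-dimethylphenyl or 4-fluorophenyl on the same amide-type nitrogen would be needed to pull them apart. Also open, on these data alone, is how far the number would fall with a phenyl carrying an amine or a carboxylic acid in this place, and whether the size of these steps holds on any core other than the shared one.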